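Compound 1 to compound 4: sulfonyl aryl swap

This account rests on a few compounds, and the source may have more. Where it says the series, first, only, none or still open, it means among the compounds named here.

compound 1 `N#Cc1ccc(O[C@H]2CN(S(=O)(=O)c3ccc(C(F)(F)F)cc3)C[C@@]2(O)CO)cc1F` gives 2 h
compound 2 `N#Cc1ccc(O[C@H]2CN(S(=O)(=O)c3ccc(Cl)cc3Cl)C[C@]2(O)CO)cc1F` gives 4.8 h
compound 3 `N#Cc1ccc(O[C@H]2CN(S(=O)(=O)c3ccccc3C#N)C[C@@]2(O)CO)cc1F` gives 0.4 h

In an ADME assay on the whole organism (Rattus norvegicus, strain Sprague-Dawley), read by LC-MS, with a stated time of 30 min, at a dose of 1 mg/kg by the intravenous route (on this read-out higher numbers stand for a longer-lived compound and lower numbers for a shorter-lived compound), compound 1 stands at 2 h in the middle of the three numbers, below compound 2 and above compound 3. Compound 4 `N#Cc1ccc(O[C@H]2CN(S(=O)(=O)c3ccc(Cl)cn3)C[C@@]2(O)CO)cc1F` is not yet measured. Its change from compound 1 is 5-chloropyridin-2-yl in place of 4-(trifluoromethyl)phenyl on a sulfonyl sulfur in short 5-chloropyridin-2-yl in place of 4-(trifluoromethyl)phenyl on a sulfonyl sulfur. Among the measured compounds shown here, only one measured step bears on it: a 5.0-fold lower number from compound 1 to compound 3 (0.70 log units; beyond the scatter) with 2-cyanophenyl entering at the same place. That single step, with a different entering group, suggests a direction but fixes no size. Expected in this assay is therefore a 2.2-fold lower number from compound 1 to compound 4 (0.35 log units; beyond the scatter) in the same direction but smaller than that step. For compound 4 the estimated value is 0.9 h with an expected range from 0.35 h to 2.3 h as a working figure.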

Compound 4, mean residence time: 1.2 h
Beside the measured number, compound 4's estimate is 1.3-fold (0.12 log units) below it; low and high end bracket the measured number.
By their numbers in this assay, from the lowest: compound 3; then compounds 4 and 1 (each within the scatter of the next); then compound 2.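

Putting 5-chloropyridin-2-yl on the sulfonyl sulfur gives a 1.7-fold lower number from compound 1 to compound 4 (0.22 log units; within the scatter) in this assay and so stays close to compound 1 on this read-out. The drop seen with 2-cyanophenyl therefore does not follow from every replacement of 4-(trifluoromethyl)phenyl at this place, as a 3.0-fold higher number from compound 3 to compound 4 (0.48 log units; beyond the scatter) shows for the same read-out. No supporting measurement explains either step.

As far as these compounds go, whether the chlorine or the ring nitrogen of 5-chloropyridin-2-yl sets this read-out stays open. So does the effect of an aryl ring carrying an amine or a carboxylic acid on the sulfonyl sulfur.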